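Alkoxyindole maleimide series: lipophilicity notes

The compounds below may be only part of what the source reports. "The series", "measured", "known", "first", "only" and "open" are said of these compounds alone.

Measured so far:
compound 1 `CCCCCOc1ccc2[nH]c(-c3ccc(OC)cc3)c(C3=C(Br)C(=O)NC3=O)c2c1` — 3.77
compound 2 `CCCCCCOc1ccc2[nH]c(-c3ccc(OC)cc3)c(C3=C(Br)C(=O)NC3=O)c2c1` — 4.1

In a physicochemical assay for lipophilicity (a higher number here means a more lipophilic compound, a lower number a more polar compound), compound 2 stands highest of the two numbers; its nearest neighbour is compound 1, which sits lower by the step of a number 0.33 log units higher from compound 1 to compound 2 (beyond the scatter), a change of methyl in place of hydrogen on a saturated chain carbon, five bonds along the chain from an oxygen on an aromatic ring.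

Compound 3 `CCCCCCOc1ccc2[nH]c(-c3cccc(OC)c3)c(C3=C(Br)C(=O)NC3=O)c2c1` is not yet measured. It differs from compound 2 by 3-methoxyphenyl in place of 4-methoxyphenyl on an aromatic carbon. Among the compounds with values here, no measured step touches this part of the molecule; the only step known, from compound 1 to compound 2, concerns the chain and does not bear on it. The two have the same atoms, joined differently, so for this assay no step beyond the scatter is expected: the estimated step is no change at the digits printed from compound 2 to compound 3 (within the scatter). For compound 3 the expected value is 4.1, in the range 3.8 to 4.4.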

Compound 3, partition coefficient: 3.92
The estimate for compound 3 lay 0.18 log units above the measured number; low and high end bracket the measured number.
By their numbers in this assay, from the lowest: compounds 1, 3 and 2 (each within the scatter of the next, the first and the last beyond it).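

In this assay, within the data shown here, the exchange of 4-methoxyphenyl for 3-methoxyphenyl gives a number 0.18 log units lower from compound 2 to compound 3 (within the scatter) and is the first reading on the aromatic carbon next to the ring nitrogen, as the earlier step concerned only the chain. With the long chain of compound 2 kept in place, this assay therefore does not separate the two methoxyphenyl isomers, so moving the methoxy group around this ring has shown no change beyond the scatter so far. Nothing measured on hand bears on the size of this step.

As far as these compounds go, whether the same exchange gives a step within the scatter with the shorter chain of compound 1 remains open. So does the reading for an amine or a carboxylic acid on this phenyl ring in place of the methoxy group.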